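The source may report more compounds than this note shows. Statements on the series, on what has been measured and on what is new or still open speak of the compounds shown alone.

In an ADME assay on HepG2 cells (Homo sapiens) for cytotoxicity, read by CellTiter-Glo, with a stated time of 48 h (on this read-out lower numbers stand for higher toxicity in this test and higher numbers for lower toxicity in this test), compound 1 `Cc1ccc(-c2nc3cc(Cl)c(Cl)cc3nc2-c2ccccc2)cc1` gives > 100000 nM, which is a limit of the assay. Compound 2 `CCCCNc1nc2ccccc2nc1S(C)(=O)=O`, which has a butyl chain, gives 12600 nM. Compound 3 `CCCCNc1nc2cc(OC)ccc2nc1S(C)(=O)=O` carries methoxy in place of hydrogen on an aromatic carbon and gives > 100000 nM, also a limit. That change is an at least 7.9-fold higher number from compound 2 to compound 3 (0.89 log units; beyond the scatter). Compound 3 therefore stands at the limit of > 100000 nM in this assay, at which 2 of the 3 values shown sit, with no number of its own.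

Compound 4 `COc1ccc2nc(S(C)(=O)=O)c(NCCC(C)C)nc2c1` keeps the methoxy and differs from compound 3 by methyl in place of hydrogen on a saturated chain carbon bound to two saturated chain carbons, which turns butyl to isopentyl. Within the data shown here, the only measured step, an at least 7.9-fold higher number from compound 2 to compound 3 (0.89 log units; beyond the scatter), concerns an aromatic carbon and not the chain, so it offers no guide to the size of this change. No change beyond the scatter is therefore expected in this assay, and the reading will probably stay at the limit. The expected step is a number no higher from compound 3 to compound 4 (the limit leaves the size open). For compound 4 the estimated value is 100000 nM, with an expected range of 40000 nM to 200000 nM.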

Compound 4, half-maximal cytotoxic concentration: 50100 nM
Compound 4: the middle estimate sits 2.0-fold (0.30 log units) above what was measured; the measured number falls inside the stated range.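

Among these compounds, the change of butyl to isopentyl gives an at least 1.9-fold lower number from compound 3 to compound 4 (0.30 log units; that floor lies within the scatter) in this assay, the first measured change on the saturated chain and not on an aromatic carbon. With methoxy kept in place, compound 4 has a number of its own, which compound 3 lacks. The true size of this step cannot be told, because compound 3 stands only at a limit: the limit of > 100000 nM in this assay, at which 2 of the 4 values shown sit.

On these data alone, whether the same methyl would change the reading with hydrogen in place of methoxy stays open, as this chain change is seen in a single pair. Also open, as far as these compounds go, is what a longer chain, or an amine at the end of the chain, would give in this assay, and whether an isopentyl chain would behave alike with fluorine in place of methoxy.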